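Naphthalen-2-yl for 4-fluorophenyl: an untested step in cytotoxicity

A few compounds are considered here, and "the series" means these few. Any claim that something is new, unique, unknown or untested is made for them only; others in the source may bear on it.

Measured so far:
compound 1, `CO[C@@H]1[C@@H](OC)[C@H](c2ccccc2)O[C@@H]2CO[C@@H](c3cccc(Cl)c3)O[C@@H]12`, >= 40 ug/mL
compound 2, `CO[C@@H]1[C@@H](OC)[C@H](c2ccccc2)O[C@@H]2CO[C@@H](c3ccc(F)cc3)O[C@@H]12`, "not determined" (no result reported)

Compound 1 carries the shared core with a 3-chlorophenyl group, and in a functional assay on HEL cells (Homo sapiens) for cytotoxicity (on this read-out higher numbers stand for lower toxicity in this test and lower numbers for higher toxicity in this test), compound 1 gives >= 40 ug/mL, which is a limit of the assay and not a number. Compound 2, `CO[C@@H]1[C@@H](OC)[C@H](c2ccccc2)O[C@@H]2CO[C@@H](c3ccc(F)cc3)O[C@@H]12`, has no result in this assay; for compound 2 the record shows "not determined" (no result reported). So compound 2 has no single number to stand on, and the only further value on this read-out is the limit of compound 1, (the limit of >= 40 ug/mL in this assay, at which 1 of the 2 values shown sits).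

Compound 3, `CO[C@@H]1[C@@H](OC)[C@H](c2ccccc2)O[C@@H]2CO[C@@H](c3ccc4ccccc4c3)O[C@@H]12`, differs from compound 2 by naphthalen-2-yl in place of 4-fluorophenyl on a saturated ring carbon. Among the compounds with values here, no measured step of this kind exists here, so the size and direction of the change in this assay cannot be taken from the data; any shift within the usual scatter or a modest one in either direction is open. Compound 3 is expected to show roughly 30 ug/mL, within 8 ug/mL to 100 ug/mL, with a fair chance of again only a limit.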

Compound 3, minimum cytotoxic concentration: >= 16 ug/mL
Compound 3 was reported as a limit; the forecaster's own chance of this, stated with the estimate: 45%; the middle value is on the limit's open side.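

Within the data shown here, compound 1 and compound 3 are both reported only as limits in this assay, so no step between them can be read. The compounds shown leave open how 3-chlorophenyl, 4-fluorophenyl and naphthalen-2-yl on the shared core compare, and at what concentration any of these compounds becomes toxic to the cells.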